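The source may report more compounds than this note shows. Statements on the series, on what has been measured and on what is new or still open speak of the compounds shown alone.

Measured in an assay on isolated protein for inhibition of kallikrein-7 (Homo sapiens), read by fluorescence, with stated times of 10 min and 30 min; a higher number here means a weaker inhibitor, a lower number a stronger inhibitor:

- compound 2, `CC1=NC(c2cn(S(=O)(=O)c3ccc(Cl)cc3)c3ccc(C)cc23)CN1`: 1900 nM
- compound 3, `CC1=NC(c2cn(S(=O)(=O)c3ccc(Cl)cc3)c3ccc(Br)cc23)CN1`: 4700 nM
- compound 1, `Cc1ccc(S(=O)(=O)n2cc(C3CNC(C(C)C)=N3)c3ccccc32)cc1`: 70000 nM

Among these three, compound 2 stands lowest in this assay: its nearest neighbour is compound 3, at a 2.5-fold higher number from compound 2 to compound 3 (0.39 log units; beyond the scatter), and the furthest is compound 1, whose value lies well beyond the scatter from that of compound 2. Compound 1 and compound 2 differ in more than one place, so their values show only that the two differ widely.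

The step considered here leads from compound 2 to compound 4, `CC1=NC(c2cn(S(=O)(=O)c3c(Cl)cccc3Cl)c3ccc(C)cc23)CN1`. The change is 2,6-dichlorophenyl in place of 4-chlorophenyl on a sulfonyl sulfur. Among the compounds with values here, none of the measured steps bears on this change: the one measured step, from compound 2 to compound 3, alters a group on the core, not the aryl on the sulfonyl sulfur, and it was modest. Within the data shown here, with no comparable step in hand, the size and direction of the change in this assay cannot be anchored in the data; a move of some size in either direction is possible. Compound 4 is therefore expected to give about 4000 nM, with a range from 1000 nM to 20000 nM, which corresponds to an expected step of a 2.1-fold higher number from compound 2 to compound 4 (0.32 log units; beyond the scatter).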

Compound 4, half-maximal inhibitory concentration: 14000 nM
Compound 4: middle estimate off by 3.5-fold (0.54 log units), on the low side; low and high end bracket the measured number.
By their numbers in this assay, from the lowest: compound 2; then compound 3; then compound 4; then compound 1.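

In this assay, the aryl on the sulfonyl sulfur proved to be a place where the inhibition of kallikrein-7 responds to change, a point the earlier single-place step on the core could not show. Putting 2,6-dichlorophenyl in place of 4-chlorophenyl gave a 7.4-fold higher number from compound 2 to compound 4 (0.87 log units; beyond the scatter), so this change weakened the inhibitor by an amount beyond the scatter. No measurement shown here accounts for the loss of strength.

The two groups differ in both the number and the placing of their chlorines, so this single step cannot separate those two contributions. From the compounds shown here alone, whether a carboxylic acid, an amine or a methoxy group on this aryl would restore or improve inhibition, and whether the same change would act alike with the bromo core of compound 3, remains open.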